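The source may hold more compounds than are shown below. What is called first, only, known or untested is meant among the compounds shown, and "the series" means these compounds.

Measured so far:
compound 1, `COc1cc(-c2cc(/C=C/C(=O)c3ccc(Cl)c(Cl)c3)[nH]n2)cc(OC)c1OC`: 79%
compound 2, `COc1ccc(-c2cc(/C=C/C(=O)c3ccc(N)cc3)[nH]n2)cc1OC`: 21%

In a functional assay on NCI-H23 cells (Homo sapiens) for cytotoxicity, read by sulforhodamine B assay, with a stated time of 48 h, tested at 10 uM (a higher number here means a weaker effect of the compound at the concentration tested, a lower number a stronger effect), compound 1 gives 79%, the higher of the two numbers recorded, and the gap to compound 2 lies beyond the scatter. Compound 2 gives 21% in this assay. Within the data shown here, compound 2 differs from compound 1 in more than one place, so the pair gives no single step that could be carried over.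

Compound 3, `COc1ccc(C(=O)/C=C/c2cc(-c3cc(OC)c(OC)c(OC)c3)n[nH]2)cc1OC`, is not yet measured. It differs from compound 1 by 3,4-dimethoxyphenyl in place of 3,4-dichlorophenyl on a carbonyl carbon. Among the measured compounds shown here, no measured pair shows this change, so its size and direction are unknown; the only other number, that of compound 2, sits far lower, but that compound is altered elsewhere as well.

The number for compound 3 is therefore expected near 65%, within 30% to 95%. A step of about a number 14 percentage points lower from compound 1 to compound 3 (beyond the scatter) is expected, with little confidence in its direction.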

Compound 3, a percentage reported as activity, at one concentration (the size of the read-out at that concentration, not a potency): -36%
Compound 3: the middle estimate sits 101 percentage points above what was measured, and the stated range ends above it.
By their numbers in this assay, from the lowest: compound 3; then compound 2; then compound 1.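

In this assay, among these compounds, the group on the carbonyl carbon proves to be far from silent: 3,4-dimethoxyphenyl in place of 3,4-dichlorophenyl gives a number 115 percentage points lower from compound 1 to compound 3 (beyond the scatter) and is the first single-place step. The change takes the read-out of compound 3 (-36%) below zero, so the core of compound 1 can carry a much stronger effect at the concentration tested once this one group is exchanged. Nothing at hand accounts for the size of this step.

As far as these compounds go, it remains open whether the step follows from losing the chlorine atoms or from gaining the methoxy groups, and a single methoxy group or a nitrile on this phenyl ring would separate the two. Whether the same exchange holds with other groups elsewhere on the core also stays unresolved.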